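Amide Group Change and Cell Toxicity in Four Analogues

The source may hold more compounds than are shown below. What is called first, only, known or untested is meant among the compounds shown, and "the series" means these compounds.

Compound 1 `O=C(Nc1nnc(-c2cccc(O)c2O)s1)c1ccc(Cl)cc1` and compound 2 `O=C(Nc1nnc(-c2ccc(O)c(O)c2)s1)c1ccc(Cl)cc1` are built from the same atoms joined differently; the difference between the two cores is not broken down here. In an ADME assay on MRC5 cells (Homo sapiens) for cytotoxicity, read by MTT assay, with a stated time of 72 h (on this read-out higher numbers stand for weaker inhibition and lower numbers for stronger inhibition), compound 1 gives 18700 nM, and compound 2 gives 30600 nM, a gap that lies within the usual scatter. Compound 3 `CC(=O)Nc1nnc(-c2cccc(O)c2O)s1` differs from compound 1 by methyl in place of 4-chlorophenyl on a carbonyl carbon and in this assay compound 3 gives 156000 nM, so the measured step was an 8.3-fold higher number from compound 1 to compound 3 (0.92 log units; beyond the scatter). Compound 4 `CC(=O)Nc1nnc(-c2ccc(O)c(O)c2)s1` has not yet been measured; it differs from compound 2 by methyl in place of 4-chlorophenyl on a carbonyl carbon, the same change at the same place. Because the step of an 8.3-fold higher number from compound 1 to compound 3 (0.92 log units; beyond the scatter) lay beyond the scatter, a step of similar size is expected here: a 7.5-fold higher number from compound 2 to compound 4 (0.88 log units; beyond the scatter). Compound 4 is accordingly estimated at 230000 nM in this assay, with a likely range from 90000 nM to 600000 nM.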

Compound 4, half-maximal inhibitory concentration: 58600 nM
Compound 4: middle estimate off by 3.9-fold (0.59 log units), on the high side, outside the stated range (below it).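

In this assay putting methyl in place of 4-chlorophenyl on a carbonyl carbon gives a 1.9-fold higher number from compound 2 to compound 4 (0.28 log units; within the scatter) on the core of compound 2 and does not repeat the size it had on the core of compound 1. The size of this step therefore depends on which of these two cores carries it: the same change on two cores in this assay, an 8.3-fold higher number (0.92 log units; beyond the scatter) from compound 1 to compound 3 and a 1.9-fold higher number (0.28 log units; within the scatter) from compound 2 to compound 4, 4.4-fold (0.64 log units) apart, beyond the scatter of two such steps. This shows that a step measured on one core was a poor guide to the other here, but it does not show what in the two cores causes the gap, and two pairs set no rule for the wider series.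

The compounds shown leave open how the two cores respond to other groups on the same carbonyl carbon, such as an amine or a longer chain. On these data alone, whether the steps would differ between the cores for those groups also remains unknown.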